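The source may report more compounds than this note shows. Statements on the series, on what has been measured and on what is new or still open speak of the compounds shown alone.

Measured so far:
- compound 1 `CCOC(=O)c1sc(N/N=C/c2c(-c3ccc([N+](=O)[O-])cc3)[nH]c3ccccc23)nc1C` at 50000 nM in an ADME assay on BJ cells (Homo sapiens) for cytotoxicity, read by fluorescence, with a stated time of 24 h; a lower number here means a stronger inhibitor, a higher number a weaker inhibitor
- compound 2 `CCC1S/C(=N\N=C\c2c(-c3ccc([N+](=O)[O-])cc3)[nH]c3ccccc23)NC1=O` at 29800 nM in this assay

Compound 1 and compound 2 stand within the scatter of each other, and neither separates from the other. Compound 3 `CCOC(=O)c1sc(N/N=C/c2c(-c3ccc(Cl)cc3)[nH]c3ccccc23)nc1C` keeps the core of compound 1, with chloro in place of nitro on an aromatic carbon, para to a large group (chloro in place of nitro on an aromatic carbon). Within the data shown here, no measured step covers this change, so no shift beyond the scatter is expected in this assay. The estimated 1.3-fold lower number from compound 1 to compound 3 (0.10 log units; within the scatter) stays within that scatter. For compound 3 the expected value is 40000 nM, with an estimated range of 15000 nM to 100000 nM.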

Compound 3, half-maximal inhibitory concentration: > 50000 nM
Compound 3: only a limit was reported; the forecaster's own chance of this, stated with the estimate: 30%; at least 1.2-fold (0.09 log units) between middle value and limit.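

In this assay compound 3 gives > 50000 nM, which is a limit of the assay and not a number. Chloro in place of nitro on an aromatic carbon, para to a large group, is the only single change shown in the series, and in this assay it brings a number no lower from compound 1 to compound 3 (the limit leaves the size open). The size of the step from compound 1 to compound 3 cannot be read because the reading ends at a limit: the limit of > 50000 nM in this assay, at which 1 of the 3 values shown sits.

Going by these compounds, whether an amine or a carboxylic acid at this position would lower the number in this assay stays open. The compounds shown also leave open how the same change would read on the core of compound 2.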